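This account rests on a few compounds, and the source may have more. Where it says the series, first, only, none or still open, it means among the compounds named here.

Measured compounds in a physicochemical assay for lipophilicity, measured as octanol-water partition; a higher number here means a more lipophilic compound, a lower number a more polar compound:
- compound 1 `O=C(NNc1ccnc2cc(Cl)ccc12)c1ccccc1/N=C/c1ccccc1Cl`: 5.5
- compound 2 `O=C(NNc1ccnc2cc(Cl)ccc12)c1ccccc1/N=C/c1ccc(Cl)cc1Cl`: 6.22
- compound 3 `O=C(NNc1ccnc2cc(Cl)ccc12)c1ccccc1/N=C/c1ccc(Cl)c(Cl)c1`: 6.22

Compound 3 stands level with compound 2 at the digits shown, the two together the highest of the three numbers; the step up from the lowest number is a number 0.72 log units higher from compound 1 to compound 3 (beyond the scatter), and between compound 2 and compound 3 there is no change at the digits printed from compound 2 to compound 3 (within the scatter).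

Compound 4 `O=C(NNc1ccnc2cc(Cl)ccc12)c1ccccc1/N=C/c1ccc(Br)cc1` differs from compound 3 in one place: 4-bromophenyl in place of 3,4-dichlorophenyl on a carbon with a double bond to nitrogen.

The step that bears on this is the addition of one chloro, a number 0.72 log units higher from compound 1 to compound 2 (beyond the scatter), and the parallel a number 0.72 log units higher from compound 1 to compound 3 (beyond the scatter). Going to compound 4 removes one chlorine and exchanges the remaining one for bromine, so a modest downward step in this assay is expected, a number 0.52 log units lower from compound 3 to compound 4 (beyond the scatter), landing between compound 1 and compound 3. For compound 4 the expected value is 5.7, range 5.3 to 6.1.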

Compound 4, partition coefficient: 5.76
The estimate for compound 4 lay 0.06 log units below the measured number, within the range that was stated.
By their numbers in this assay, from the lowest: compounds 1 and 4 (each within the scatter of the next); then compounds 2 and 3 (each within the scatter of the next).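

In this assay the 4-bromophenyl group gives a number 0.46 log units lower from compound 3 to compound 4 (beyond the scatter) and a number 0.46 log units lower from compound 2 to compound 4 (beyond the scatter), so it does not match either dichlorophenyl group at this place. Set against 2-chlorophenyl, it gives a number 0.26 log units higher from compound 1 to compound 4 (within the scatter), leaving the four compounds as two groups: compound 1 with compound 4, and compound 2 with compound 3. Nothing available gives a reason for these steps.

Still open, on these data alone, is how a phenyl group carrying an amine or a carboxylic acid would read on this carbon. Also open, as far as these compounds go, is whether bromine and chlorine would compare the same way on the shared core with a second halogen present.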